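This account rests on a few compounds, and the source may have more. Where it says the series, first, only, none or still open, it means among the compounds named here.

In a functional assay on HOP-62 cells (Homo sapiens) for cytotoxicity, read by resazurin assay, with a stated time of 72 h (on this read-out higher numbers stand for weaker inhibition and lower numbers for stronger inhibition), compound 1 `O=C(/C=C/c1ccc(OCCCCO[N+](=O)[O-])c(O)c1)OCCCCO[N+](=O)[O-]` reads > 50000 nM, which is a limit of the assay and not a number. Compound 2 `COc1cc(/C=C/C(=O)OCCCCCO[N+](=O)[O-])ccc1O` gives 12500 nM. Compound 3 `O=C(/C=C/c1ccc(O)c(O)c1)OCc1c(-c2ccccc2)no[n+]1[O-]` gives 6120 nM, the lower of the two actual numbers, and its gap to compound 2 lies beyond the usual scatter. Compound 4 `COc1cc(/C=C/C(=O)OCc2c(-c3ccccc3)no[n+]2[O-])ccc1O` differs from compound 3 in one place: methyl in place of hydrogen on an oxygen on an aromatic ring, with methyl in place of hydrogen on an oxygen on an aromatic ring, so that 3,4-dihydroxyphenyl becomes 4-hydroxy-3-methoxyphenyl. Compound 2 also carries 4-hydroxy-3-methoxyphenyl and gives 12500 nM, which points towards modestly weaker inhibition. The expected step of a 1.5-fold higher number from compound 3 to compound 4 (0.17 log units; within the scatter) is a small rise, close to the scatter. Compound 4 is estimated at 9000 nM, within an expected range of 3500 nM to 25000 nM.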

Compound 4, half-maximal inhibitory concentration: 8660 nM
Beside the measured number, compound 4's estimate is 1.0-fold (0.02 log units) above it; measured number inside the range.
By their numbers in this assay, from the lowest: compounds 3, 4 and 2 (each within the scatter of the next, the first and the last beyond it). At a limit, above all of these: compound 1.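

In this assay, going from hydroxy to methoxy on the aromatic ring gives a 1.4-fold higher number from compound 3 to compound 4 (0.15 log units; within the scatter), so capping this oxygen with methyl leaves the reading within the scatter. The earlier compounds shown here differed in more than one place and could not isolate this change. Nothing measured here gives a cause for this step.

From the compounds shown here alone, whether a larger group on this oxygen, such as benzyl, or an amine in place of the hydroxy would shift the number remains open. So does whether the same change behaves alike on the core of compound 2.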